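Swapping the aromatic ring on an amide-type nitrogen

The source may hold more compounds than are shown below. What is called first, only, known or untested is meant among the compounds shown, and "the series" means these compounds.

Values so far in an ADME assay on a cell-free system (plasma, Homo sapiens) for metabolic stability; on this read-out higher numbers stand for a longer-lived compound and lower numbers for a shorter-lived compound
- compound 1 `COC(=O)N1C(=O)[C@@H](C)[C@@H]2[C@@H]1CCN2C(=O)OCc1ccccc1` gives 0.833 h
- compound 2 `C[C@@H]1C(=O)N(c2ccc([N+](=O)[O-])cc2)[C@H]2CCN(C(=O)OCc3ccccc3)[C@H]12` gives 40 h

Compound 2 holds the higher of the two numbers. Compound 3 `C[C@@H]1C(=O)N(c2nccs2)[C@H]2CCN(C(=O)OCc3ccccc3)[C@H]12` carries 1,3-thiazol-2-yl in place of 4-nitrophenyl on an amide-type nitrogen in a ring. Among the compounds with values here, the only measured step at this place is large and beyond the scatter (a 48-fold higher number from compound 1 to compound 2 (1.68 log units; beyond the scatter)), but it replaced methoxycarbonyl with an aromatic ring. Compound 3 keeps an aromatic ring there, so it is expected to stay far from compound 1 and closer to compound 2 (40 h). In this assay a moderate fall is expected (a 2.7-fold lower number from compound 2 to compound 3 (0.43 log units; beyond the scatter)). Compound 3 is estimated at 15 h (range 3 h to 50 h).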

Compound 3, half-life: 44 h
The estimate for compound 3 lay 2.9-fold (0.47 log units) below the measured number; the range from low to high includes it.
By their numbers in this assay, from the lowest: compound 1; then compounds 2 and 3 (each within the scatter of the next).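

In this assay, the two aromatic rings cannot be told apart (a 1.1-fold higher number from compound 2 to compound 3 (0.04 log units; within the scatter)), so a five-membered aromatic ring with 2 hetero atoms matches a six-membered aromatic ring of carbon only on this amide-type nitrogen. Set against methoxycarbonyl, 1,3-thiazol-2-yl also gives a large step (a 53-fold higher number from compound 1 to compound 3 (1.72 log units; beyond the scatter)), so two different aromatic rings now stand far from compound 1. No measurement here explains why these groups behave this way.

Still open, going by these compounds, is whether a non-aromatic group such as cyclohexyl would stay close to compound 2 or fall towards compound 1, and the same goes for a plain acetyl group. Only such a group could show whether an aromatic ring is needed here at all.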